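Nitro-methoxy enaminone series: methoxy addition on the aroyl ring

The source may hold more compounds than are shown below. What is called first, only, known or untested is meant among the compounds shown, and "the series" means these compounds.

Of the compounds shown here, three have been measured in a functional assay on A549 cells (Homo sapiens) for antiproliferative activity, read by sulforhodamine B assay, with a stated time of 48 h; on this read-out lower numbers stand for stronger inhibition and higher numbers for weaker inhibition. Compound 1 `COc1cc(OC)c2sc(-c3ccc(N/C=C\C(=O)c4ccc(OC)c([N+](=O)[O-])c4)c(C)c3)nc2c1` gives 12100 nM in this assay. Compound 2 `COc1cc(OC)c2sc(-c3ccc(N/C=C\C(=O)c4cc(OC)c(OC)c([N+](=O)[O-])c4)c(C)c3)nc2c1` differs from compound 1 by methoxy in place of hydrogen on an aromatic carbon. In this assay compound 2 gives 15400 nM; the step is a 1.3-fold higher number from compound 1 to compound 2 (0.10 log units; within the scatter). Compound 3 `COc1ccc(C(=O)/C=C\Nc2ccc(-c3nc4cc(OC)c(OC)c(OC)c4s3)cc2)cc1[N+](=O)[O-]`, on a different core, gives 21200 nM in this assay; the difference between the core of compound 3 and the core of compound 1 is not broken down here, and the values of compound 3 and compound 2 lie within the scatter of each other.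

Compound 4 `COc1cc(C(=O)/C=C\Nc2ccc(-c3nc4cc(OC)c(OC)c(OC)c4s3)cc2)cc([N+](=O)[O-])c1OC` is not yet measured. It differs from compound 3 by methoxy in place of hydrogen on an aromatic carbon, the same change as from compound 1 to compound 2, with the same surroundings at the place of change. Among the measured compounds shown here, for compound 4 in this assay a step of a 1.2-fold higher number from compound 3 to compound 4 (0.09 log units; within the scatter) is expected, because a 1.3-fold higher number from compound 1 to compound 2 (0.10 log units; within the scatter) was within the scatter for the only earlier instance of this change. Compound 4 is therefore estimated at 26000 nM, with a range from 12000 nM to 55000 nM.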

Compound 4, half-maximal inhibitory concentration: 11800 nM
The estimate for compound 4 lay 2.2-fold (0.34 log units) above the measured number; the whole stated range lies above it.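

In this assay, methoxy in place of hydrogen on an aromatic carbon, ortho to a methoxy group and meta to a nitro group, gives on the second core a 1.8-fold lower number from compound 3 to compound 4 (0.25 log units; within the scatter). Set beside the earlier instance of the same change, this step cannot be told apart from it: the same change on two cores in this assay, a 1.3-fold higher number (0.10 log units; within the scatter) from compound 1 to compound 2 and a 1.8-fold lower number (0.25 log units; within the scatter) from compound 3 to compound 4, 2.3-fold (0.36 log units) apart, within the scatter of two such steps Carrying the change from one core to the other therefore shows no dependence on the core that these data can resolve, and on neither core does the step leave the scatter, but two pairs in one cell assay do not establish that the change is without effect or that it would behave alike on further cores.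

Still open, going by these compounds, is whether another group on the same aromatic carbon, such as an amine, a hydroxyl or a longer alkoxy chain like ethoxy, would give a step beyond the scatter. Also open, on these data alone, is how the series responds when the nitro group gives way to a nitrile or a carboxylic acid.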